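Pyridine Acid in Place of the Benzoic Acid

A few compounds are considered here, and "the series" means these few. Any claim that something is new, unique, unknown or untested is made for them only; others in the source may bear on it.

Within the data shown here, compound 2 `O=C(O)c1cccc(C2CC2c2ccc(OCc3c(-c4c(Cl)cccc4Cl)noc3C3CC3)cc2Cl)c1` gives 32 nM in an assay on isolated protein for agonist activity at Bile acid receptor (Homo sapiens), read by FRET (a higher number here means that more compound is needed for the effect, a lower number that less compound is needed), the lower of the two numbers measured so far; compound 1 `O=C(O)c1cccc([C@H]2C[C@@H](c3ccc(OCc4c(-c5c(Cl)cccc5Cl)noc4C4CC4)cc3Cl)C2)c1` gives 77 nM, a gap beyond the usual scatter. Compound 3 `O=C(O)c1ccc(C2CC2c2ccc(OCc3c(-c4c(Cl)cccc4Cl)noc3C3CC3)cc2Cl)cn1` differs from compound 2 by 6-carboxypyridin-3-yl in place of 3-carboxyphenyl on a saturated ring carbon. Among the measured compounds shown here, no measured pair shows this change, so its size cannot be read from the numbers in hand; a step within or only just beyond the scatter, in either direction, seems the most plausible outcome. Compound 3 is therefore expected to give about 45 nM in this assay, in a range from 15 nM to 150 nM. That estimate means a 1.4-fold higher number from compound 2 to compound 3 (0.15 log units; within the scatter).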

Compound 3, half-maximal effective concentration: 66 nM
Compound 3: the middle estimate sits 1.5-fold (0.17 log units) below what was measured; the measured number falls inside the stated range.
By their numbers in this assay, from the lowest: compound 2; then compounds 3 and 1 (each within the scatter of the next).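

In this assay the step is a 2.1-fold higher number from compound 2 to compound 3 (0.31 log units; beyond the scatter) for 6-carboxypyridin-3-yl in place of 3-carboxyphenyl on a saturated ring carbon. This position therefore responds to a single ring nitrogen in the acid-bearing ring, though only modestly, and the number stays in the same range. Nothing measured here explains the shift. 

From the compounds shown here alone, it remains open how a pyrimidine ring carrying the carboxylic acid, or a tetrazole or primary amide in place of that acid, would read. Going by these compounds, whether the same swap gives a similar step on the core of compound 1 is also open.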